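Extending the urea tail with a methylpiperazinylmethyl group

The compounds below may be only part of what the source reports. "The series", "measured", "known", "first", "only" and "open" are said of these compounds alone.

Of the compounds shown here, two have been measured in a functional assay on U-87MG ATCC cells for antiproliferative activity against U-87 MG (Homo sapiens), read by MTT assay, with a stated time of 72 h; a higher number here means a weaker inhibitor, a lower number a stronger inhibitor. Compound 1 `COc1ncc(-c2ccc3nc(NC4CC4)sc3c2)cc1NS(=O)(=O)c1ccc(F)cc1` gives 1500 nM. Compound 2 `CNC(=O)Nc1nc2ccc(-c3cnc(OC)c(NS(=O)(=O)c4ccc(F)cc4)c3)cc2s1` gives 1230 nM. For the measured compounds named here, the single step between them, a 1.2-fold lower number from compound 1 to compound 2 (0.09 log units; within the scatter), is the only comparison available, and it shows no movement beyond the scatter. Compound 2 gives the smaller of the two numbers shown, but its gap to compound 1 is within the scatter, so neither compound can be called the stronger inhibitor.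

Compound 3 `COc1ncc(-c2ccc3nc(NC(=O)NCCN4CCN(C)CC4)sc3c2)cc1NS(=O)(=O)c1ccc(F)cc1` differs from compound 2 in one place: (4-methylpiperazin-1-yl)methyl in place of hydrogen on a saturated chain carbon bound to an amide-type nitrogen. Going by the values given here, no measured step tests this part of the molecule directly; the only step, from compound 1 to compound 2, swaps the group on that nitrogen rather than extending it, so it bears on the change only loosely, and it was within the scatter. With nothing that argues for a shift in either direction, the expected step is a 1.0-fold lower number from compound 2 to compound 3 (0.01 log units; within the scatter), that is, no change beyond the scatter. Compound 3 is therefore estimated at 1200 nM, with a range from 400 nM to 3600 nM.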

Compound 3, half-maximal inhibitory concentration: 440 nM
Compound 3: middle estimate off by 2.7-fold (0.44 log units), on the high side; the range from low to high includes it.
By their numbers in this assay, from the lowest: compound 3; then compounds 2 and 1 (each within the scatter of the next).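

The tail of the urea, which had looked insensitive, now shows that this part of the molecule can shift the number in this assay: changing methyl to 2-(4-methylpiperazin-1-yl)ethyl gives a 2.8-fold lower number from compound 2 to compound 3 (0.45 log units; beyond the scatter) and so moves it modestly. The earlier swap of cyclopropyl for methylcarbamoyl stayed within the scatter, whereas (2-(4-methylpiperazin-1-yl)ethyl)carbamoyl in the same place gives a 3.4-fold lower number from compound 1 to compound 3 (0.53 log units; beyond the scatter) and so also goes beyond it, which ties the gain in these three compounds to the added chain and ring, not to the carbamoyl alone. No measurement shown here explains how the new group produces this shift.

The compounds shown leave open whether the ring itself is needed or whether a simple dimethylamino group at the end of the same chain would do as well, and whether a morpholine ring in its place would give a similar number. They also leave open how the number responds to a longer chain, such as a propyl link to the same 4-methylpiperazine, and to removing the methyl group from that ring.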